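The source may report more compounds than this note shows. Statements on the series, on what has been measured and on what is new or still open speak of the compounds shown alone.

The study concerns a functional assay on HEK293 cells for antagonist activity at Orexin receptor type 2 (Homo sapiens), read by FLIPR and calcium flux; on this read-out higher numbers stand for higher potency (the scale is a negative logarithm) and lower numbers for lower potency. Compound 1 `Cc1ccc(-n2nccn2)c(C(=O)N2CCC3(CC3)C[C@H]2CNc2cccc(C)n2)c1` and compound 2 `Cc1ccc(-c2ncccn2)c(C(=O)N2CCC3(CC3)C[C@H]2CNc2ccc(Cl)cn2)c1` have been measured there. For compound 1 this assay reports only a limit, < 5, and not a number. For compound 2 the read-out is likewise a limit, < 5, so compound 2 stands at the edge of what the measurement resolves. Among the measured compounds shown here, both values sit at the same boundary (the limit of < 5 in this assay, at which 2 of the 2 values shown sit), and no step between measured compounds can be drawn. Compound 3 `Cc1ccc(-n2nccn2)c(C(=O)N2CCC3(CC3)C[C@H]2CNc2ccc(Cl)cn2)c1` is not yet measured. It differs from compound 2 in one place: 2H-1,2,3-triazol-2-yl in place of pyrimidin-2-yl on an aromatic carbon, the new ring sitting ortho to a large group and para to a methyl group. Compound 1 already carries the 2H-1,2,3-triazol-2-yl group and gives only the limit. The step from compound 2 to compound 3 is therefore expected to be a step that the limit leaves unreadable from compound 2 to compound 3, nothing beyond the scatter. Compound 3 is estimated at 4.9, between 4.3 and 5.6, with a fair chance that this assay again reports only a limit.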

Compound 3, negative logarithm of the antagonist equilibrium constant: < 5
Compound 3: only a limit was reported; the forecaster's own chance of this, stated with the estimate: 65%; the middle value is on the limit's open side.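

In this assay compound 3 gives < 5, which is a limit and not a number. No step from compound 2 or compound 1 to compound 3 can be read: the limit of < 5 in this assay, at which 3 of the 3 values shown sit.

The compounds shown leave open whether either change affects potency, and what any of the three compounds' actual values are.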